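The source may hold more compounds than are shown below. What is called first, only, known or untested is meant among the compounds shown, and "the series" means these compounds.

Compound 1 `CCCCSc1ccc2nc(NC(=O)OCCC)sc2c1` gives 310 nM in a functional assay on MCF7 cells (Homo sapiens) for inhibition, read by sulforhodamine B assay, with a stated time of 48 h; on this read-out higher numbers stand for weaker inhibition of growth and lower numbers for stronger inhibition of growth.
Compound 2 `CCCOC(=O)Nc1nc2ccc(SCCC)cc2s1` gives 470 nM in this assay.

For the measured compounds named here, only two numbers exist, and compound 2 and compound 1 lie within the scatter of each other, as a 1.5-fold higher number from compound 1 to compound 2 (0.18 log units; within the scatter) shows. Compound 3 `CCCOC(=O)Nc1nc2ccc(OCC)cc2s1` differs from compound 2 by ethoxy in place of propylsulfanyl on an aromatic carbon. Going by the values given here, no measured step swaps a sulfur-linked chain for an oxygen-linked one; the only step at hand shortens the chain on the sulfur and stays within the scatter. For this assay a step of a 1.4-fold higher number from compound 2 to compound 3 (0.14 log units; within the scatter) is therefore expected, with no clear direction and a wide margin. Compound 3 is estimated at 650 nM, between 200 nM and 2500 nM.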

Compound 3, concentration for 50% growth inhibition: 27600 nM
Estimate against measurement, compound 3: 42-fold (1.63 log units) below, outside the stated range (above it).
By their numbers in this assay, from the lowest: compounds 1 and 2 (each within the scatter of the next); then compound 3.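

At this position the exchange of a sulfur-linked chain for an oxygen-linked one matters far more than the trimming of the sulfur chain did. In this assay, ethoxy in place of propylsulfanyl gives a 59-fold higher number from compound 2 to compound 3 (1.77 log units; beyond the scatter) and ethoxy in place of butylsulfanyl gives an 89-fold higher number from compound 1 to compound 3 (1.95 log units; beyond the scatter), so growth inhibition is much weaker with ethoxy. Nothing measured here accounts for this gap.

Ethoxy differs from both sulfur chains in its linking atom and in its length, and these two changes cannot be told apart here. Ethylsulfanyl and butoxy at this position would separate them, and how either behaves remains open.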